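Bis-benzothiazole amines: dropping the chloro of compound 1

This account rests on a few compounds, and the source may have more. Where it says the series, first, only, none or still open, it means among the compounds named here.

Compound 1 `Clc1ccc2nc(Nc3nc4ccccc4s3)sc2c1` gives only a limit in a functional assay on B16-F10 cells (Mus musculus) for cytotoxicity, read by MTT assay, with a stated time of 48 h; on this read-out higher numbers stand for weaker inhibition and lower numbers for stronger inhibition: compound 1 sits at > 50000 nM, a limit of the assay rather than a number, (the limit of > 50000 nM in this assay, at which 1 of the 2 values shown sits). Compound 2 `Fc1ccc(NC(=S)Nc2nc3ccc(F)cc3s2)cc1` gives 47700 nM in this assay. Compound 3 `c1ccc2sc(Nc3nc4ccccc4s3)nc2c1` differs from compound 1 by hydrogen in place of chloro on an aromatic carbon. Going by the values given here, no measured step covers this change. The expected step is a number no higher from compound 1 to compound 3 (the limit leaves the size open), none beyond the scatter, and compound 3 may well also report only a limit. Compound 3 is estimated at 50000 nM, with a range from 20000 nM to 150000 nM.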

Compound 3, half-maximal inhibitory concentration: > 50000 nM
Compound 3 was reported as a limit (the forecaster's own chance of this, stated with the estimate: 70%); the middle value lies on the limit itself.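

In this assay compound 1 stands at the limit > 50000 nM. Compound 3 stands at the limit > 50000 nM, so no step can be read between compound 1 and compound 3. Going by these compounds, what hydrogen in place of chloro does in this assay stays open.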